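Moving an ester chain branch: isobutyl to tert-butyl

This account rests on a few compounds, and the source may have more. Where it says the series, first, only, none or still open, it means among the compounds named here.

Of the compounds shown here, two of a shared core have been tested in an assay on membranes from HeLa cells for displacement of a labelled ligand from adenosine receptor A3 (Homo sapiens), read by scintillation counting, with a stated time of 180 min, tested at 1 uM; a lower number here means less inhibition, a higher number more inhibition at the concentration tested (going by the name of the read-out). Compound 1, `CC1=C(C(=O)OC(C)(C)C)C(c2ccco2)NC(=S)N1`, gives 9%. Compound 2, `CC1=C(C(=O)OCC(C)C)C(c2ccoc2)NC(=S)N1`, gives 1%. Compound 2 holds the lower of the two numbers, but the gap to compound 1 lies within the usual scatter of the measurement, so the two results cannot be told apart; both show only weak displacement of the labelled ligand at the concentration tested.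

Compound 3, `CC1=C(C(=O)OC(C)(C)C)C(c2ccoc2)NC(=S)N1`, has not yet been measured. Compared with compound 2, the change is tert-butyl in place of isobutyl on an oxygen next to a carbonyl group. Within the data shown here, no single-point step between measured compounds is available to anchor the size of this change. Since compound 1 already carries the tert-butyl group and gives only 9%, while compound 2 gives 1%, the expected step of a number 3 percentage points higher from compound 2 to compound 3 (within the scatter) is small and within the scatter, without a clear direction. Compound 3 is therefore estimated at 4%, with a likely range from -6% to 14%.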

Compound 3, a percentage reported as inhibition, at one concentration (the size of the read-out at that concentration, not a potency): 19%
Beside the measured number, compound 3's estimate is 15 percentage points below it; measured number outside the range, above it.
By their numbers in this assay, from the lowest: compounds 2, 1 and 3 (each within the scatter of the next, the first and the last beyond it).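

In this assay, the step from isobutyl to tert-butyl on an oxygen next to a carbonyl group is a number 18 percentage points higher from compound 2 to compound 3 (beyond the scatter), and it is modest. It shows that two groups with the same count of heavy atoms, joined differently, can give results that are distinguishable in this read-out, something the first two compounds, which also differ in their furan group, could not show. The second step, furan-3-yl in place of furan-2-yl on a saturated ring carbon, is a number 10 percentage points higher from compound 1 to compound 3 (within the scatter), so these compounds give no readable effect of that change, and no measurement at hand explains why tert-butyl and isobutyl differ here.

On these data alone, it remains open whether the same isobutyl to tert-butyl step would appear with furan-2-yl on the shared core, and how a longer chain such as hexyl, a benzyl ester or a free carboxylic acid would read at this position. As far as these compounds go, with compound 3 at 19% at a single concentration, its potency also remains unknown, so the size of this step says little about how far a true potency difference extends.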